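A few compounds are considered here, and "the series" means these few. Any claim that something is new, unique, unknown or untested is made for them only; others in the source may bear on it.

Compound 3 `Cc1cc(C)c(CN2CCc3c(Cl)cc(-c4c(C)noc4C)c(Cl)c3C2=O)c(=O)[nH]1` gives 93000 nM in a physicochemical assay for solubility, measured as kinetic solubility (a higher number here means a more soluble compound, a lower number a less soluble compound), the lowest of the two single numbers in the set; compound 1 `Cc1cc(C)c(CN2CCc3c(Cl)cc([C@@H](CO)[C@@H]4CCOC4)c(Cl)c3C2=O)c(=O)[nH]1` gives 537000 nM, and compound 2 `COC(c1cc(Cl)c2c(c1Cl)C(=O)N(Cc1c(C)cc(C)[nH]c1=O)CC2)C1CCOCC1` gives 57500 nM; 57200 nM (2 entries) across its duplicate entries, as recorded in the several entries of compound 2 in this assay, 57500 nM; 57200 nM (2 entries). Among the compounds with values here, only one measured step bears on the exchange at this position, namely a 5.8-fold lower number from compound 1 to compound 3 (0.76 log units; beyond the scatter), where the oxolane-bearing group was replaced by the 3,5-dimethyl-1,2-oxazol-4-yl group. Compound 4 `Cc1cc(C)c(CN2CCc3c(Cl)cc([C@@H](CO)[C@H]4CCCO4)c(Cl)c3C2=O)c(=O)[nH]1` reverses that kind of exchange: a group of 8 heavy atoms (6 carbon, 2 oxygen; one five-membered non-aromatic ring with 1 hetero atom) in place of a group of 7 heavy atoms (5 carbon, 1 nitrogen, 1 oxygen; one five-membered aromatic ring with 2 hetero atoms), on an aromatic carbon. The entering group carries a hydroxymethyl and an oxolane ring, as in compound 1, though attached at a different ring position and with its own stereocentres. A step of roughly the reverse size is therefore expected in this assay, estimated as a 4.8-fold higher number from compound 3 to compound 4 (0.68 log units; beyond the scatter). Compound 4 is expected at 450000 nM, within 200000 nM to 850000 nM.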

Compound 4, solubility: 576000 nM
For compound 4 the middle estimate is 1.3-fold (0.11 log units) below the measured one; the measured number falls inside the stated range.
By their numbers in this assay, from the lowest: compound 3; then compounds 1 and 4 (each within the scatter of the next).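

In this assay, restoring a hydroxymethyl-bearing oxolane group on this aromatic carbon in place of 3,5-dimethyl-1,2-oxazol-4-yl gives a 6.2-fold higher number from compound 3 to compound 4 (0.79 log units; beyond the scatter), opposite in direction to the earlier step from compound 1. Moving the ring attachment, oxolan-2-yl in place of oxolan-3-yl, gives a 1.1-fold higher number from compound 1 to compound 4 (0.03 log units; within the scatter), so this change does not separate the two compounds. Nothing recorded for the series accounts for either step.

As far as these compounds go, the separate contributions of the hydroxymethyl group and the oxolane ring remain open. So does whether an amine or a carboxylic acid in place of the hydroxymethyl would keep the number at this level.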